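A few compounds are considered here, and "the series" means these few. Any claim that something is new, unique, unknown or untested is made for them only; others in the source may bear on it.

Compound 1, with the structure `COc1cc(NC(C)CCCNC(=O)/C=C/c2ccc(Cl)cc2)c2ncccc2c1`, is the anchor of this small set. In an ADME assay on L6 cells (Rattus norvegicus) for cytotoxicity, read by resazurin assay, with a stated time of 70 h (on this read-out higher numbers stand for weaker inhibition and lower numbers for stronger inhibition), compound 1 gives 7.1 ug/mL. Compound 2, `COc1cc(NC(C)CCCNC(=O)/C=C/c2ccc(C(F)(F)F)cc2)c2ncccc2c1`, differs from it in one place: trifluoromethyl in place of chloro on an aromatic carbon. That single exchange produced a 10-fold higher number from compound 1 to compound 2 (1.01 log units; beyond the scatter), so compound 2 gives 73.1 ug/mL in this assay. Compound 3, `COc1cc(NC(C)CCCNC(=O)Nc2cccc(Cl)c2)c2ncccc2c1`, keeps the chloro but changes the core, as (3-chlorophenyl)amino in place of 2-(4-chlorophenyl)ethenyl on a carbonyl carbon; the resulting 1.4-fold higher number from compound 1 to compound 3 (0.15 log units; within the scatter) leaves compound 3 at 10 ug/mL in this assay, a number not separable from that of compound 1.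

Compound 4, `COc1cc(NC(C)CCCNC(=O)Nc2cccc(C(F)(F)F)c2)c2ncccc2c1`, has not yet been measured. It stands to compound 3 as compound 2 stands to compound 1, through (trifluoromethyl in place of chloro on an aromatic carbon). This is the same kind of change, not the same one: in the measured pair the group sits para to a large group, whereas in compound 4 it sits meta to a large group, and the two cores differ as already told. Because the earlier step was a 10-fold higher number from compound 1 to compound 2 (1.01 log units; beyond the scatter), the expected step is a 5.0-fold higher number from compound 3 to compound 4 (0.70 log units; beyond the scatter), somewhat tempered by the changed surroundings. Compound 4 is therefore estimated at 50 ug/mL in this assay, with a likely range from 15 ug/mL to 150 ug/mL.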

Compound 4, half-maximal inhibitory concentration: 150 ug/mL
For compound 4 the middle estimate is 3.0-fold (0.48 log units) below the measured one; the range from low to high includes it.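

In this assay, trifluoromethyl in place of chloro gave a 15-fold higher number from compound 3 to compound 4 (1.18 log units; beyond the scatter), and the step carried over from one core to the other at much the same size: the same change on two cores in this assay, a 10-fold higher number (1.01 log units; beyond the scatter) from compound 1 to compound 2 and a 15-fold higher number (1.18 log units; beyond the scatter) from compound 3 to compound 4, 1.5-fold (0.16 log units) apart, within the scatter of two such steps For a newcomer, the practical reading is that on these two cores the exchange moved the number the same way, towards weaker inhibition of the cells, even though the two cores differ and the group does not sit in the same place on the ring in the two pairs. Within the data shown here, this shows agreement between only two pairs in a single assay, so it sets no rule for other cores and does not explain why the number rises.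

The compounds shown leave open whether other groups in the same place, such as bromo or a nitrile, would give a similar step. Also open, as far as these compounds go, is whether a longer chain on the shared core, or moving the group around the ring on a single core, would change the size of this step.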